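A few compounds are considered here, and "the series" means these few. Any claim that something is new, unique, unknown or untested is made for them only; others in the source may bear on it.

In a functional assay on CCRF-CEM cells (Homo sapiens) for cytotoxicity, in the absence of a further agent (a lower number here means a stronger inhibitor, a higher number a weaker inhibitor), compound 1 `COC(=O)c1ccc(CN(CCCc2c(N)nc(N)nc2O)c2cc(F)cc(F)c2[N+](=O)[O-])cc1` gives > 100000 nM, which is a limit of the assay and not a number. Compound 2 `Nc1nc(N)c(CCCN(Cc2ccc(NC(CCC(=O)O)C(=O)O)cc2)c2cc(F)c([N+](=O)[O-])cc2[N+](=O)[O-])c(O)n1` gives 40000 nM and compound 3 `COC(=O)c1ccc(CN(CCCc2c(N)nc(N)nc2O)c2cc(F)c(F)cc2[N+](=O)[O-])cc1` gives 59000 nM, two values within the scatter of each other. Compound 4 `Nc1nc(N)c(CCCN(Cc2ccc(NC(CCC(=O)O)C(=O)O)cc2)c2cc(F)c(F)cc2[N+](=O)[O-])c(O)n1` differs from compound 3 by having (1,3-dicarboxypropyl)amino in place of methoxycarbonyl on an aromatic carbon, para to a large group: (1,3-dicarboxypropyl)amino in place of methoxycarbonyl on an aromatic carbon. Among the measured compounds shown here, no measured step covers this exchange. For the measured compounds named here, the one step available, an at least 1.6-fold lower number from compound 1 to compound 3 (0.22 log units; that floor lies within the scatter), changes the group on the amine nitrogen instead, and its floor lies within the scatter, so it says little here. The closest guide is compound 2 at 40000 nM, which already carries (1,3-dicarboxypropyl)amino, although its group on the amine nitrogen is different. In this assay the expected move is therefore no larger than the scatter, and the estimated step is a 1.2-fold lower number from compound 3 to compound 4 (0.07 log units; within the scatter). Compound 4 is expected at about 50000 nM, with an estimated range of 15000 nM to 100000 nM.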

Compound 4, half-maximal inhibitory concentration: > 100000 nM
Compound 4: no number, only a limit; the forecaster's own chance of this, stated with the estimate: 25%; middle value at least 2.0-fold (0.30 log units) away from the limit.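

In this assay compound 4 stands at a limit of the assay and not at a number: the limit of > 100000 nM in this assay, at which 2 of the 4 values shown sit. At the aromatic carbon para to a large group, (1,3-dicarboxypropyl)amino in place of methoxycarbonyl gives an at least 1.6-fold higher number from compound 3 to compound 4 (0.22 log units; that floor lies within the scatter), so this exchange is not shown to shift the result. With (1,3-dicarboxypropyl)amino held constant, fluoro in place of nitro on an aromatic carbon gives an at least 2.5-fold higher number from compound 2 to compound 4 (0.39 log units; beyond the scatter), which is the first step among these compounds to lie beyond the scatter.

On these data alone, the true size of both steps stays open, as each ends on a limit. Also open, as far as these compounds go, is what a simple carboxylic acid or a primary amine would give at this aromatic carbon in place of methoxycarbonyl.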